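The compounds below may be only part of what the source reports. "The series", "measured", "known", "first", "only" and "open" are said of these compounds alone.

Measured compounds, in a toxicity assay on L02 cells (Homo sapiens) for cytotoxicity, read by MTT assay, with a stated time of 72 h; on this read-out lower numbers stand for stronger inhibition and higher numbers for weaker inhibition:
compound 1, `CN1CCN(CCCCCn2c3c(c4ccccc42)C(=O)c2c[n+]([O-])c4ccccc4c2C3=O)CC1`, gives 1640 nM
compound 2, `O=C1c2c[n+]([O-])c3ccccc3c2C(=O)c2c1c1ccccc1n2Cc1cn(C[C@@H](O)CO)nn1`, gives 490 nM
compound 3, `CC1(C)O[C@@H](CO)[C@H](Cn2cc(Cn3c4c(c5ccccc53)C(=O)c3c[n+]([O-])c5ccccc5c3C4=O)nn2)O1`, gives 500 nM

All three share one core and differ only in the group on the aromatic nitrogen of the five-membered ring. Compound 2 has the lowest number of the three, but its neighbour compound 3 sits within the scatter: a 1.0-fold higher number from compound 2 to compound 3 (0.01 log units; within the scatter). Within the data shown here, the one clear step is a 3.3-fold lower number from compound 1 to compound 2 (0.52 log units; beyond the scatter), so compound 2 can be called no more than the joint lower end of this small set.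

Compound 4, `O=C1c2c[n+]([O-])c3ccccc3c2C(=O)c2[nH]c3ccccc3c21`, is the bare core: hydrogen in place of (1-(2,3-dihydroxypropyl)-1H-1,2,3-triazol-4-yl)methyl on an aromatic nitrogen. Among the measured compounds shown here, no measured step removes the whole side group; the two steps known only swap one side group for another at this position. As far as these compounds go, one such swap was modest, the other did nothing, so the site tolerates change, but what a hydrogen does there is untested. A step of modest size, more likely toward a higher number, is therefore expected, a 2.0-fold higher number from compound 2 to compound 4 (0.31 log units; beyond the scatter), with wide uncertainty. Compound 4 is estimated at 1000 nM, in a range from 300 nM to 3500 nM.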

Compound 4, half-maximal inhibitory concentration: 400 nM
Compound 4: the middle estimate sits 2.5-fold (0.40 log units) above what was measured; the measured number falls inside the stated range.
By their numbers in this assay, from the lowest: compounds 4, 2 and 3 (each within the scatter of the next); then compound 1.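

In this assay, removing the whole side group leaves the number within the scatter: a 1.2-fold lower number from compound 2 to compound 4 (0.09 log units; within the scatter). The earlier compounds shown here only swapped one side group for another, so they could not show that the shared core with a plain hydrogen on this aromatic nitrogen already sits level with compound 2, and that the (1-(2,3-dihydroxypropyl)-1H-1,2,3-triazol-4-yl)methyl group is not needed to reach that number. Compound 1 now stands apart from the bare core as well as from compound 2, with a 4.1-fold lower number from compound 1 to compound 4 (0.61 log units; beyond the scatter), and no measurement at hand accounts for either step.

The compounds shown leave open whether the higher number of compound 1 goes with the 4-methylpiperazine ring or with the pentyl chain that carries it, a question that a plain pentyl chain, or the same chain ending in a primary amine, could help to settle. Also open, as far as these compounds go, is how a single methyl or a short chain ending in a carboxylic acid would compare with hydrogen on this nitrogen.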